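The source may hold more compounds than are shown below. What is called first, only, known or untested is meant among the compounds shown, and "the series" means these compounds.

Of the compounds shown here, three built on a shared core have been tested so far in an ADME assay on HeLa cells (Homo sapiens) for cytotoxicity, read by MTT assay; on this read-out lower numbers stand for stronger inhibition and higher numbers for weaker inhibition. Compound 1 `COc1ccc(C[C@H]2COC(=O)[C@@H]2Cc2ccc(OCc3cn(Cc4ccc(F)cc4)nn3)c(OC)c2)cc1OC` gives 198000 nM. Compound 3 `COc1ccc(C[C@H]2COC(=O)[C@@H]2Cc2ccc(OC(=O)CCC(=O)N3CCCCC3)c(OC)c2)cc1OC` gives 128000 nM, which is within the scatter of compound 1. Compound 2 `COC(=O)[C@H](CC(C)C)NC(=O)CCC(=O)Oc1ccc(C[C@H]2C(=O)OC[C@@H]2Cc2ccc(OC)c(OC)c2)cc1OC` gives 53200 nM, a number lower than that of compound 1 by more than the scatter.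

Compound 4 `COc1ccc(C[C@H]2COC(=O)[C@@H]2Cc2ccc(OCc3cn(-c4ccc(Cl)cc4)nn3)c(OC)c2)cc1OC` keeps the core of compound 1 and changes one group: 4-chlorophenyl in place of 4-fluorobenzyl on an aromatic nitrogen. Within the data shown here, no measured pair differs at this place, so the data give no direct guide to this change.

Among the measured compounds shown here, the only measured step, a 2.4-fold higher number from compound 2 to compound 3 (0.38 log units; beyond the scatter), is modest and lies on a carbonyl carbon, a different place in the molecule. It therefore offers only a rough idea of how far one group exchange has moved the number on this core. A step of similar or smaller size seems reasonable here, so no change beyond the scatter is expected, and the direction remains uncertain. The estimated step is a 1.3-fold lower number from compound 1 to compound 4 (0.12 log units; within the scatter). For compound 4 the estimated value is 150000 nM, with an expected range from 60000 nM to 350000 nM.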

Compound 4, half-maximal inhibitory concentration: 279000 nM
Compound 4: the middle estimate sits 1.9-fold (0.27 log units) below what was measured; the range from low to high includes it.
By their numbers in this assay, from the lowest: compound 2; then compounds 3, 1 and 4 (each within the scatter of the next, the first and the last beyond it).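

In this assay, among these compounds, replacing 4-fluorobenzyl with 4-chlorophenyl on an aromatic nitrogen of the five-membered ring gives a 1.4-fold higher number from compound 1 to compound 4 (0.15 log units; within the scatter), the first direct reading at this position. This single exchange changes two things together, the halogen on the ring and the carbon link between that ring and the nitrogen, yet the number does not move beyond the usual scatter, so this position tolerates this combined change without a clear shift in the read-out. Nothing measured here explains this result.

The pair cannot separate the halogen from the carbon link, and the two could have effects that offset each other, so 4-fluorophenyl and 4-chlorobenzyl on the same nitrogen would be the telling comparisons. As far as these compounds go, it also remains open whether this position would stay as tolerant with a quite different group, such as a 4-aminophenyl, a 4-carboxyphenyl or a longer chain such as 2-phenylethyl, since both groups compared here are halogen-bearing aromatic rings.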